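The source may report more compounds than this note shows. Statements on the series, on what has been measured and on what is new or still open speak of the compounds shown alone.

Measured so far:
compound 1 `Cc1ccc2c(Cc3nn4cc(-c5ccc(Cl)cc5)nc4s3)coc2c1`: 8.38%
compound 2 `Cc1ccc2c(Cc3nn4c(/C=N/O)c(-c5ccc(Cl)cc5)nc4s3)coc2c1`: 6%

Both compounds share one core and differ at a single aromatic carbon. In a functional assay on the whole organism (strain Wistar albino) for inhibition, with Rattus norvegicus as the target, read by paw edema, with a stated time of 0.5 h, at a dose of 100 mg/kg by the oral route (a lower number here means less inhibition, a higher number more inhibition at the dose given (going by the name of the read-out)), compound 1 gives 8.38%, and compound 2 gives 6%. Among the compounds with values here, the one known step, a number 2.4 percentage points lower from compound 1 to compound 2 (within the scatter), puts a group of 3 heavy atoms in place of a hydrogen atom, and the numbers of compound 1 and compound 2 cannot be told apart; the inhibition of compound 2 in this assay is level with that of compound 1.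

Compound 3 `Cc1ccc2c(Cc3nn4c(C#N)c(-c5ccc(Cl)cc5)nc4s3)coc2c1` is the next step from compound 2. The change is a group of 2 heavy atoms (1 carbon, 1 nitrogen; no ring) in place of a group of 3 heavy atoms (1 carbon, 1 nitrogen, 1 oxygen; no ring), on an aromatic carbon. Within the data shown here, only the step from compound 1 to compound 2 bears on this, as it concerns the same aromatic carbon, and it stayed within the scatter. Among the measured compounds shown here, nothing among the measured compounds points to a larger effect for a cyano at that place, so a step of no more than the scatter is expected, a number 1 percentage points higher from compound 2 to compound 3 (within the scatter). Compound 3 is therefore estimated at 7%, in a range from 0% to 20%.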

Compound 3, a percentage reported as inhibition, in the whole organism at one dose (the size of the read-out at that dose, not a potency): 4.77%
Estimate against measurement, compound 3: 2.2 percentage points above; the measured number falls inside the stated range.
By their numbers in this assay, from the lowest: compounds 3, 2 and 1 (each within the scatter of the next).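

In this assay the new result gives a number 1.2 percentage points lower from compound 2 to compound 3 (within the scatter) and, with cyano in place of hydrogen on the same aromatic carbon, a number 3.6 percentage points lower from compound 1 to compound 3 (within the scatter). At this carbon, next to the ring nitrogen and next to the ring atom that bears the 4-chlorophenyl group, hydrogen, the group with 1 hydrogen-bond donor and cyano with 0 hydrogen-bond donors therefore cannot be told apart in this read-out, so the presence of that donor shows no effect here that exceeds the scatter. No other measurement shown here helps to interpret this result.

The compounds shown leave open whether a quite different group on this carbon, such as an amine, a carboxylic acid or a longer chain, would produce a step beyond the scatter. They also leave open whether the same changes would remain within the scatter if the 4-chlorophenyl group gave way to another group, such as a plain phenyl ring.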